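Replacing 3,4-Dinitrophenyl with 3,4-Dihydroxyphenyl

A few compounds are considered here, and "the series" means these few. Any claim that something is new, unique, unknown or untested is made for them only; others in the source may bear on it.

In a functional assay on RS4-11 cells (Homo sapiens) for inhibition, read by CCK-8 assay, with a stated time of 48 h (a higher number here means a weaker inhibitor, a lower number a stronger inhibitor), compound 1 `O=C(NCCNS(=O)(=O)c1ccc(-c2ccccc2O[C@H]2CC[C@@H](O)CC2)s1)Nc1cc(C(F)(F)F)cc(C(F)(F)F)c1` gives 9300 nM, while compound 2 `O=C(NCCNS(=O)(=O)c1ccc(-c2ccccc2Oc2ccc([N+](=O)[O-])c([N+](=O)[O-])c2)s1)Nc1cc(C(F)(F)F)cc(C(F)(F)F)c1` gives 2400 nM, the lower of the two numbers. Compound 3 `O=C(NCCNS(=O)(=O)c1ccc(-c2ccccc2Oc2ccc(O)c(O)c2)s1)Nc1cc(C(F)(F)F)cc(C(F)(F)F)c1` carries 3,4-dihydroxyphenyl in place of 3,4-dinitrophenyl on an oxygen on an aromatic ring. Within the data shown here, only one measured step bears on this place, the modest 3.9-fold lower number from compound 1 to compound 2 (0.59 log units; beyond the scatter), with 3,4-dinitrophenyl in place of 4-hydroxycyclohexyl. That step concerns a different exchange and gives no firm direction, so a change beyond the scatter is not expected, and the estimated step is a 1.3-fold higher number from compound 2 to compound 3 (0.10 log units; within the scatter). The estimate for compound 3 is 3000 nM, with an expected range of 800 nM to 10000 nM.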

Compound 3, half-maximal inhibitory concentration: 4900 nM
The estimate for compound 3 lay 1.6-fold (0.21 log units) below the measured number, within the range that was stated.
By their numbers in this assay, from the lowest: compound 2; then compounds 3 and 1 (each within the scatter of the next).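

In this assay, the group on this oxygen still separates two aromatic rings: 3,4-dihydroxyphenyl in place of 3,4-dinitrophenyl gives a 2.0-fold higher number from compound 2 to compound 3 (0.31 log units; beyond the scatter) and leaves compound 2 with the lowest number of the three. Against 4-hydroxycyclohexyl, the same group gives a 1.9-fold lower number from compound 1 to compound 3 (0.28 log units; within the scatter) and so is not separated from it here. Nothing measured here accounts for either step.

The compounds shown leave open whether both nitro groups are needed for the lower number of compound 2. They also leave open how an amine or a carboxylic acid on this phenyl ring would read.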